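The source may report more compounds than this note shows. Statements on the series, on what has been measured and on what is new or still open speak of the compounds shown alone.

Compound 1 `CNC(=O)/C=C1/COc2cc(OS(=O)(=O)c3ccccc3)ccc21` gives 0% in an assay (strain Sprague-Dawley) for inhibition of Amine oxidase [flavin-containing] B (Rattus norvegicus), read by spectrophotometry, with a stated time of 5 min, tested at 10 uM; a lower number here means less inhibition, a higher number more inhibition at the concentration tested (going by the name of the read-out). Compound 2 `CNC(=O)/C=C1/COc2cc(OS(=O)(=O)c3cccc(Cl)c3)ccc21` gives 0% in this assay, a step of no change at the digits printed from compound 1 to compound 2 (within the scatter), so compound 2 stands level with compound 1. Compound 3 `CNC(=O)/C=C1/COc2cc(OS(=O)(=O)c3cccc(C#N)c3)ccc21` differs from compound 2 by cyano in place of chloro on an aromatic carbon. Among the measured compounds shown here, the only measured step that bears on substitution at this aromatic carbon, no change at the digits printed from compound 1 to compound 2 (within the scatter), was flat, and both compound 1 with 0% and compound 2 with 0% show no inhibition at the concentration tested. No movement beyond the scatter is therefore expected from compound 2 to compound 3, a step estimated as no change at the digits printed from compound 2 to compound 3 (within the scatter). Compound 3 is expected to give 0%, in the range 0% to 10%.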

Compound 3, a percentage reported as inhibition, at one concentration (the size of the read-out at that concentration, not a potency): 0%
For compound 3 middle estimate and measured number coincide at the digits printed, within the range that was stated.
By their numbers in this assay, from the lowest: compounds 1, 2 and 3 (each within the scatter of the next).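

In this assay the change from 3-chlorophenyl to 3-cyanophenyl gives no change at the digits printed from compound 2 to compound 3 (within the scatter) and the same group set against hydrogen gives no change at the digits printed from compound 1 to compound 3 (within the scatter). A second substituent on this aromatic carbon, now one with a triple bond and a hydrogen-bond acceptor, therefore joins chloro in leaving the read-out unmoved, with compound 3 at 0% in this assay. Nothing available explains this flat result. As far as these compounds go, what an amine or a carboxylic acid on this carbon would do remains open. Also open, from the compounds shown here alone, is whether a change elsewhere on the shared core, such as a longer chain on the amide, would move the read-out.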